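This account rests on a few compounds, and the source may have more. Where it says the series, first, only, none or still open, it means among the compounds named here.

Compound 1 `Cc1nc(N[C@H](C)c2cccc(C(F)F)c2F)c2cc3c(cc2n1)OCC[C@H]1CN(C(=O)c2cccnc2)CCN31`: 3180 ng.h/mL
Compound 2 `Cc1nc(N[C@H](C)c2cccc(C(F)F)c2F)c2cc3c(cc2n1)OCC[C@H]1CN(C)CCN31`: 3250 ng.h/mL

In an ADME assay on the whole organism (Mus musculus, strain ICR) for pharmacokinetics, read by LC-MS, with a stated time of 24 h, at a dose of 50 mg/kg by the oral route (a lower number here means less compound in the circulation, a higher number more compound in the circulation at the dose given), compound 2 gives 3250 ng.h/mL, level with compound 1 within the scatter. Compound 3 `Cc1nc(N[C@H](C)c2cccc(C(F)F)c2F)c2cc3c(cc2n1)OCC[C@H]1CN(CC2COC2)CCN31` differs from compound 2 as follows: oxetan-3-yl in place of hydrogen on a saturated chain carbon bound to an amine nitrogen in a ring. In words, methyl becomes (oxetan-3-yl)methyl on the amine nitrogen in a ring. Going by the values given here, only one measured step bears on this, a change of group on that same nitrogen, methyl in place of (pyridin-3-yl)carbonyl: a 1.0-fold higher number from compound 1 to compound 2 (0.01 log units; within the scatter). That single step gives no sign of a shift, so none beyond the scatter is expected, and the estimated step is a 1.1-fold lower number from compound 2 to compound 3 (0.03 log units; within the scatter). Compound 3 is expected at 3000 ng.h/mL, with an estimated range of 1300 ng.h/mL to 7000 ng.h/mL.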

Compound 3, area under the concentration-time curve: 10700 ng.h/mL
For compound 3 the middle estimate is 3.6-fold (0.55 log units) below the measured one; the whole stated range lies below it.
By their numbers in this assay, from the lowest: compounds 1 and 2 (each within the scatter of the next); then compound 3.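

In this assay, oxetan-3-yl in place of hydrogen on a saturated chain carbon bound to an amine nitrogen in a ring gives a 3.3-fold higher number from compound 2 to compound 3 (0.52 log units; beyond the scatter) as its result. Replacing (pyridin-3-yl)carbonyl with (oxetan-3-yl)methyl gives a 3.4-fold higher number from compound 1 to compound 3 (0.53 log units; beyond the scatter) on the same nitrogen. The group on this nitrogen can therefore change the number beyond the scatter, which the earlier pair did not show. Nothing available explains the rise. Still open, from the compounds shown here alone, is whether the oxetane ring itself matters, or whether a plain ethyl group or a longer ether chain such as 2-methoxyethyl would give a similar number.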